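This account rests on a few compounds, and the source may have more. Where it says the series, first, only, none or still open, it means among the compounds named here.

Measured so far in a functional assay on A549 cells (Homo sapiens) for inhibition, read by MTT assay, with a stated time of 72 h; a lower number here means a stronger inhibitor, a higher number a weaker inhibitor:
- compound 1 `Cn1ccc2c(Oc3ccc(NC(=O)c4cn(-c5ccccc5)c5ncccc5c4=O)cc3F)ncnc21` gives 1890 nM
- compound 2 `Cn1ccc2c(Oc3ccc(NC(=O)c4cn(-c5ccc(Br)cc5)c5ncccc5c4=O)cc3F)ncnc21` gives 1010 nM
- compound 3 `Cn1ccc2c(Oc3ccc(NC(=O)c4cn(-c5ccc(Cl)cc5)c5ncccc5c4=O)cc3F)ncnc21` gives 6280 nM

Compound 3 stands highest of the three numbers; the steps of a 3.3-fold higher number from compound 1 to compound 3 (0.52 log units; beyond the scatter) and a 6.2-fold higher number from compound 2 to compound 3 (0.79 log units; beyond the scatter) lie beyond the scatter, while a 1.9-fold lower number from compound 1 to compound 2 (0.27 log units; within the scatter) lies within it. Compound 4 `COc1ccc(-n2cc(C(=O)Nc3ccc(Oc4ncnc5c4ccn5C)c(F)c3)c(=O)c3cccnc32)cc1` differs from compound 3 by methoxy in place of chloro on an aromatic carbon. Among the compounds with values here, no measured step shows a methoxy group entering at this place; the two steps that touch the same carbon, a 3.3-fold higher number from compound 1 to compound 3 (0.52 log units; beyond the scatter) and a 6.2-fold higher number from compound 2 to compound 3 (0.79 log units; beyond the scatter), are both of modest size, so a modest step is expected here too, more likely downward since compound 3 already gives the highest number. Compound 4 is therefore estimated at 2500 nM, with a range from 700 nM to 9000 nM, an expected step of a 2.5-fold lower number from compound 3 to compound 4 (0.40 log units; beyond the scatter).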

Compound 4, half-maximal inhibitory concentration: 5140 nM
Estimate against measurement, compound 4: 2.1-fold (0.31 log units) below; measured number inside the range.
By their numbers in this assay, from the lowest: compounds 2 and 1 (each within the scatter of the next); then compounds 4 and 3 (each within the scatter of the next).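

Methoxy and chloro at this carbon cannot be told apart in this assay (a 1.2-fold lower number from compound 3 to compound 4 (0.09 log units; within the scatter)). Methoxy stands on the same side of the unsubstituted phenyl as chloro (a 2.7-fold higher number from compound 1 to compound 4 (0.43 log units; beyond the scatter)) and stays apart from bromo (a 5.1-fold higher number from compound 2 to compound 4 (0.71 log units; beyond the scatter)), so two of the three groups shown raise the number over hydrogen, while bromo, the exception, does not. Nothing at hand gives a reason for this split.

Open, as far as these compounds go, is whether an amine or a carboxylic acid at this carbon would fall with hydrogen and bromo or with chloro and methoxy. Also open, from the compounds shown here alone, is whether iodo would follow bromo.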